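The compounds below may be only part of what the source reports. "The series", "measured", "known", "first", "only" and "open" are said of these compounds alone.

Measured compounds:
compound 1 `Cc1nn(-c2ncnc3nc[nH]c23)c2c1C(C(=O)N(C)c1nccs1)CC(=O)N2` — 18 nM
compound 2 `Cc1nn(-c2ncnc3nc[nH]c23)c2c1C(C(=O)NCc1ccc(F)cc1)CC(=O)N2` — 4 nM
compound 3 `C/C(=N\NC(=O)c1cc2ccccc2cc1O)c1ccc(N)cc1` — 1100 nM

In a functional assay on HEK293 cells for agonist activity at G-protein coupled receptor 39 (Homo sapiens), read by scintillation proximity assay and inositol phosphate accumulation, with a stated time of 75 min, in the presence of a further agent that is not named here (a lower number here means that less compound is needed, a higher number that more compound is needed for the effect), compound 1 gives 18 nM, the second highest of the three numbers. Its nearest neighbour is compound 2, reached by a 4.5-fold lower number from compound 1 to compound 2 (0.65 log units; beyond the scatter); the furthest is compound 3, whose 1100 nM is far higher and whose structure shares nothing with the core of compound 1.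

Compound 4 `Cc1nn(-c2ncnc3nc[nH]c23)c2c1C(NC(=O)c1ccccc1)CC(=O)N2` differs from compound 1 at the same saturated ring carbon: benzamido in place of methyl(1,3-thiazol-2-yl)carbamoyl on a saturated ring carbon. For the measured compounds named here, the only step that bears on it is the one from compound 1 to compound 2, which also replaced the group on that carbon and was modest. Here, however, the amide is joined the other way round, so that step is only a loose guide. Compound 4 is therefore expected to lie close to compound 1, with a 2.2-fold higher number from compound 1 to compound 4 (0.35 log units; beyond the scatter) likely small and of uncertain direction. The estimate for compound 4 is 40 nM, within the range 8 nM to 200 nM.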

Compound 4, half-maximal effective concentration: 3 nM
Beside the measured number, compound 4's estimate is 13-fold (1.12 log units) above it; measured number below the stated range.
By their numbers in this assay, from the lowest: compounds 4 and 2 (each within the scatter of the next); then compound 1; then compound 3.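

Replacing methyl(1,3-thiazol-2-yl)carbamoyl with benzamido on the saturated ring carbon gives a 6.0-fold lower number from compound 1 to compound 4 (0.78 log units; beyond the scatter) in this assay, so this position keeps a low number even with the amide joined the other way round. Compound 4 at 3 nM and compound 2 at 4 nM lie within the scatter of each other, although their amides run in opposite directions. No available evidence accounts for this step. Still open, on these data alone, is whether an amine or a carboxylic acid on that carbon would keep the number low, and whether a longer chain between the amide and the benzene ring would do so.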